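The source may hold more compounds than are shown below. What is called first, only, known or untested is meant among the compounds shown, and "the series" means these compounds.

Measured so far in a toxicity assay on THP-1 cells (Homo sapiens) for inhibition; a higher number here means that more compound is tolerated, a lower number that less compound is tolerated:

- compound 1 `COc1ccc(-c2cnc(NC(=O)c3ccco3)n2C)cc1`: > 100000 nM
- compound 2 `COc1ccc(-c2cnc(NC(=O)c3ccn[nH]3)n2C)cc1`: > 100000 nM
- compound 3 `COc1ccc(-c2cnc(NC(=O)C3CCOCC3)n2C)cc1`: > 100000 nM

Each of these three results is a limit of the assay rather than a number. For compound 1 the result in this assay is the limit > 100000 nM. For compound 2 the result is likewise the limit > 100000 nM. For compound 3 the result is again the limit > 100000 nM. All three share one core and differ only in the group on the carbonyl carbon, yet none of the comparisons between them can be read: a step that the two limits leave unreadable from compound 1 to compound 2, a step that the two limits leave unreadable from compound 1 to compound 3, and a step that the two limits leave unreadable from compound 2 to compound 3. The reason is the limit of > 100000 nM in this assay, at which 3 of the 3 values shown sit, so compound 2 stands at that limit together with the other two, with no ordering among them.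

Compound 4 `COc1ccc(-c2cnc(NC(=O)c3cc(-c4ccccn4)n[nH]3)n2C)cc1` has not been measured. It differs from compound 2 in one place: pyridin-2-yl in place of hydrogen on an aromatic carbon. Among the measured compounds shown here, since every measured step is unreadable, no step in this assay gives a size or a direction for this change, and compound 2 itself offers only a limit as the starting point. The expectation is therefore a small step, if any, from the limit: an at least 1.2-fold lower number from compound 2 to compound 4 (0.09 log units; that floor lies within the scatter) is the estimated step. Compound 4 is expected to give about 80000 nM in this assay, within the range 25000 nM to 200000 nM.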

Compound 4, half-maximal cytotoxic concentration: >= 50000 nM
Compound 4: a limit, no number; the forecaster's own chance of this, stated with the estimate: 55%; the middle value does not contradict the limit.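

Compound 4 gives >= 50000 nM, which is a limit of the assay and not a number. Compound 2 also has only a limit, so the step between compound 2 and compound 4 cannot be read. The compounds shown leave open what concentration of any of them would be toxic to the cells, and whether pyridin-2-yl in place of hydrogen changes it.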